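This account rests on a few compounds, and the source may have more. Where it says the series, first, only, none or still open, it means among the compounds named here.

Compound 1 `CC1=C(C(=O)Nc2ccccc2)C(c2cn(-c3ccccc3)nc2-c2ccccc2)NC(=S)N1` gives 88200 nM in a functional assay on MCF7 cells (Homo sapiens) for inhibition, read by sulforhodamine B assay, with a stated time of 24 h (on this read-out lower numbers stand for stronger inhibition of growth and higher numbers for weaker inhibition of growth), the highest of the two numbers; its nearest neighbour, compound 2 `CC1=C(C(=O)Nc2ccc(C)cc2)C(c2cn(-c3ccccc3)nc2-c2ccccc2)NC(=S)N1`, gives 56100 nM, and the step of a 1.6-fold lower number from compound 1 to compound 2 (0.20 log units; within the scatter) comes from methyl in place of hydrogen on an aromatic carbon. Compound 3 `CC1=C(C(=O)Nc2ccccc2)C(c2cn(-c3ccccc3)nc2-c2ccc(Cl)cc2)NC(=S)N1` differs from compound 1 by chloro in place of hydrogen on an aromatic carbon, para to a large group, phenyl to 4-chlorophenyl. Going by the values given here, no measured step touches that ring, and the one step seen stayed within the scatter. For compound 3 a step of a 1.3-fold lower number from compound 1 to compound 3 (0.10 log units; within the scatter) is therefore expected, nothing beyond the scatter. Compound 3 is estimated at 70000 nM, within 25000 nM to 200000 nM.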

Compound 3, concentration for 50% growth inhibition: 61500 nM
Estimate against measurement, compound 3: 1.1-fold (0.06 log units) above; the range from low to high includes it.
By their numbers in this assay, from the lowest: compounds 2, 3 and 1 (each within the scatter of the next).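

In this assay, phenyl to 4-chlorophenyl gives a 1.4-fold lower number from compound 1 to compound 3 (0.16 log units; within the scatter), so a single chloro at this place, on a ring the methyl step did not touch, stays within the scatter. With the step to compound 2, two separate single-atom changes on compound 1 have now been read, and neither goes beyond the scatter. No evidence bears on this result.

As far as these compounds go, whether an amine, a carboxylic acid or a longer chain at this place would move the number beyond the scatter remains open. So does the effect of chloro elsewhere on this ring.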